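Adding a second fluoro to compound 2

The compounds below may be only part of what the source reports. "The series", "measured", "known", "first", "only" and "open" are said of these compounds alone.

Compound 1 `O=C(Nc1ccc(F)c(-c2nc3ncc(-c4ccc(F)c(F)c4)cc3[nH]2)c1)N1CCCC1`: > 50000 nM (a limit, not a number)
Compound 2 `O=C(Nc1ccc(F)c(-c2nc3ncc(-c4cccc(F)c4)cc3[nH]2)c1)N1CCCC1`: 28200 nM

Within the data shown here, in an ADME assay on HepG2 cells (Homo sapiens) for cytotoxicity, read by resazurin assay, with a stated time of 48 h (a higher number here means that more compound is needed for the effect, a lower number that less compound is needed), compound 2 gives 28200 nM, the only true number so far. The result for compound 1 is a limit. Compound 3 `O=C(Nc1ccc(F)c(-c2nc3ncc(-c4cc(F)cc(F)c4)cc3[nH]2)c1)N1CCCC1` differs from compound 2 by fluoro in place of hydrogen on an aromatic carbon, which turns 3-fluorophenyl into 3,5-difluorophenyl. Among the measured compounds shown here, the one measured step that bears on this, an at least 1.7-fold lower number from compound 1 to compound 2 (0.24 log units; that floor lies within the scatter), runs the opposite way, taking a fluoro off, and only its floor is known. A step within the scatter is therefore expected in this assay, if anything towards a higher number. The expected step is a 1.2-fold higher number from compound 2 to compound 3 (0.09 log units; within the scatter). The estimate for compound 3 is 35000 nM, with an expected range from 16000 nM to 60000 nM.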

Compound 3, half-maximal effective concentration: > 50000 nM
Compound 3: a limit, no number; the forecaster's own chance of this, stated with the estimate: 30%; at least 1.4-fold (0.15 log units) between middle value and limit.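

Adding a fluoro at this place on the ring gives an at least 1.7-fold higher number from compound 2 to compound 3 (0.24 log units; that floor lies within the scatter) in this assay, so only the smallest possible size of the step is known. The result for compound 3 is a limit, not a number, and the step between compound 1 and compound 3 cannot be read. Both 3,4-difluorophenyl and 3,5-difluorophenyl end at the same limit: the limit of > 50000 nM in this assay, at which 2 of the 3 values shown sit.

On these data alone, whether these two compounds differ beyond that limit stays open. So does how an amine or a carboxylic acid in this place on the ring would read in this assay.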